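A few compounds are considered here, and "the series" means these few. Any claim that something is new, unique, unknown or untested is made for them only; others in the source may bear on it.

Compound 1 `Cc1ccc2nc(C(=O)Nc3c(F)cc(-c4cccc(F)c4)cc3F)c(C)c(O)c2c1`, in a functional assay on A-375 cells (Homo sapiens) for antiproliferative activity, read by MTT assay, with a stated time of 24 h, tested at 0.41 ug/mL (on this read-out higher numbers stand for a stronger effect at the one concentration tested and lower numbers for a weaker effect), gives 1.35%; compound 2 `Cc1c(C(=O)Nc2c(F)cc(-c3cccc(F)c3)cc2F)nc2ccc(OC(F)(F)F)cc2c1O` gives 1.02%, and the two numbers are within the scatter of each other, as a number 0.3 percentage points lower from compound 1 to compound 2 (within the scatter) shows. Compound 3 `Cc1ccc2nc(C(=O)Nc3c(F)cc(-c4cccc(F)c4)cc3F)c(C)c(C(=O)O)c2c1` has not been measured. It differs from compound 1 by carboxy in place of hydroxy on an aromatic carbon. Among the compounds with values here, no measured step touches the hydroxy or a carboxy; the only step known changes a remote methyl and is within the scatter. For compound 3 the expected step is therefore a number 0.2 percentage points higher from compound 1 to compound 3 (within the scatter), none beyond the scatter. Compound 3 is estimated at 1.5%, in the range 0% to 12%.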

Compound 3, a percentage reported as inhibition, at one concentration (the size of the read-out at that concentration, not a potency): 1.53%
For compound 3 the middle estimate is 0 percentage points below the measured one; low and high end bracket the measured number.
By their numbers in this assay, from the lowest: compounds 2, 1 and 3 (each within the scatter of the next).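

Within the data shown here, at the aromatic carbon opposite the ring nitrogen, the step of a number 0.2 percentage points higher from compound 1 to compound 3 (within the scatter) in this assay is the first reading at this position. Exchanging hydroxy for carboxy, with three heavy atoms entering in place of one, does not move the read-out beyond the scatter, so this position now joins the remote methyl site in showing no separation. No evidence bears on why this exchange leaves the number within the scatter.

As far as these compounds go, whether an amine or a methyl ester at this position would move the number beyond the scatter remains open. Also open, from the compounds shown here alone, is whether carboxy and trifluoromethoxy together would do so.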